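Nitro in Place of Methyl on the Aromatic Ring

The source may hold more compounds than are shown below. What is called first, only, known or untested is meant among the compounds shown, and "the series" means these compounds.

Compound 1, `CC1=CC[C@H](C(C)C)c2cc(C)c(OC(=O)c3ccc(C)cc3)cc21`, is the anchor of this small set: in a functional assay on HCT-15 cells (Homo sapiens) for antiproliferative activity, read by sulforhodamine B assay, with a stated time of 48 h, tested at 50 uM (on this read-out lower numbers stand for less inhibition and higher numbers for more inhibition at the one concentration tested (going by the name of the read-out)), compound 1 gives 78.9%, the only result reported as a number. Compound 2, `Cc1cc2c(C(C)C)ccc(C)c2cc1OC(=O)c1cccc(C(F)(F)F)c1`, rests on a different core and carries a trifluoromethyl group; in this assay compound 2 is recorded as "not active" (no number reported), so it offers no number to compare against. Compound 3, `CC1=CC[C@H](C(C)C)c2cc(C)c(OC(=O)c3ccc([N+](=O)[O-])cc3)cc21`, keeps the core of compound 1 and differs from it in one place: nitro in place of methyl on an aromatic carbon. For the measured compounds named here, no two measured compounds here differ by a single change, so there is no measured step that shows how such a swap plays out. The expected step is therefore cautious: a number 8.9 percentage points lower from compound 1 to compound 3 (within the scatter) is estimated to be small, within the usual scatter or a mild drop. Compound 3 is estimated at 70%, with a plausible range from 45% to 90%.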

Compound 3, a percentage reported as inhibition, at one concentration (the size of the read-out at that concentration, not a potency): 67.8%
Compound 3: the middle estimate sits 2.2 percentage points above what was measured; measured number inside the range.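

In this assay, for the compounds shown here, the swap of 4-methylphenyl to 4-nitrophenyl gives a number 11.1 percentage points lower from compound 1 to compound 3 (beyond the scatter) and provides the first measured single change in this set. At this place on the ring, para to a large group, nitro in place of methyl therefore lowers the inhibition but does not abolish it, and compound 3 still gives 67.8% at the one concentration tested. No supporting evidence bears on this result, so the step stands without an explanation.

A single step cannot show how other groups would read at this place, such as an amine, a carboxylic acid or a longer chain. Compound 2 has a different core and no number, so it does not help to settle this.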